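The source may report more compounds than this note shows. Statements on the series, on what has been measured and on what is new or still open speak of the compounds shown alone.

Series notes. Going by the values given here, compound 1 `COc1cc2ncnc(Nc3ccc(NC(=O)c4ccccc4C)cc3)c2cc1OC` in a functional assay on MCF7 cells (Homo sapiens) for inhibition, read by MTT assay (a higher number here means a weaker inhibitor, a lower number a stronger inhibitor), gives 21000 nM, the only true number in the set so far. Compound 2 `COc1cc2ncnc(Nc3ccc(NC(=O)c4cccc(C(F)(F)F)c4)cc3)c2cc1OC` in this assay returns only a limit of the assay, > 100000 nM. The step from compound 1 to compound 2 is an at least 4.7-fold higher number from compound 1 to compound 2 (0.67 log units; beyond the scatter), bounded by the limit of > 100000 nM in this assay, at which 1 of the 2 values shown sits, rather than closed by a number. Compound 3 `COc1cc2ncnc(Nc3ccc(NC(=O)c4ccc(C(F)(F)F)cc4)cc3)c2cc1OC` is not yet measured; it differs from compound 1 as 4-(trifluoromethyl)phenyl in place of 2-methylphenyl on a carbonyl carbon, a change sitting on the same carbonyl carbon as the step to compound 2. That single step is the only one bearing on it and points toward a weaker inhibitor, so a step of the same direction is expected, a 3.8-fold higher number from compound 1 to compound 3 (0.58 log units; beyond the scatter), though the 4-(trifluoromethyl)phenyl itself is not directly covered. Compound 3 is therefore estimated at 80000 nM, within 30000 nM to 250000 nM, with a fair chance this assay again reports only a limit.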

Compound 3, half-maximal inhibitory concentration: > 100000 nM
Compound 3: a limit, no number; the forecaster's own chance of this, stated with the estimate: 50%; middle value at least 1.2-fold (0.09 log units) from the limit.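

On the carbonyl carbon, 4-(trifluoromethyl)phenyl in place of 2-methylphenyl moves this assay in the same direction as the 3-(trifluoromethyl)phenyl of compound 2, with an at least 4.7-fold higher number from compound 1 to compound 3 (0.67 log units; beyond the scatter). Compound 3 gives > 100000 nM, which is a limit and not a number, so this step has a lower bound only. The step between compound 2 and compound 3 cannot be read, and nothing here orders these two trifluoromethyl compounds: the limit of > 100000 nM in this assay, at which 2 of the 3 values shown sit.

Still open, as far as these compounds go, is whether the trifluoromethyl group itself goes with the weaker result or whether the 2-methylphenyl of compound 1 is what keeps a measurable value. An unsubstituted phenyl, or a phenyl carrying an amine or a carboxylic acid in place of the trifluoromethyl, on the same carbonyl carbon would help separate these two readings.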